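Cyclohexyl for 4-chlorobenzyl on the amine of compound 1

This account rests on a few compounds, and the source may have more. Where it says the series, first, only, none or still open, it means among the compounds named here.

Compound 1 `Cc1cc(CNCc2ccc(Cl)cc2)c(C)n1-c1ccc(Cl)cc1` was read in an ADME assay on THP-1 cells (Homo sapiens) for cytotoxicity, read by trypan blue exclusion, with a stated time of 48 h (on this read-out lower numbers stand for stronger inhibition of growth and higher numbers for weaker inhibition of growth), where compound 1 gives 18 ug/mL. Among the three measured compounds this is the second highest number. Compound 2 `Cc1cc(CN2CCN(c3ccccc3)CC2)c(C)n1-c1ccc(Cl)cc1` gives 25 ug/mL, which sits within the scatter of the value of compound 1, so the two cannot be told apart. Compound 3 `Cc1c(CN2CCN(C)CC2)cc(-c2ccc(Cl)cc2)n1-c1ccc(Cl)cc1`, which carries a second 4-chlorophenyl on the shared core, gives 3.23 ug/mL, a lower number that lies beyond the scatter relative to compound 1.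

Compound 4 `Cc1cc(CNC2CCCCC2)c(C)n1-c1ccc(Cl)cc1` has not been measured. Relative to compound 1 the change is cyclohexyl in place of 4-chlorobenzyl on an amine nitrogen. Among the compounds with values here, no measured pair shows this exact change, so its size is unknown; the only comparison available is that the compound bearing an extra 4-chlorophenyl, compound 3, gives the lowest number. Removing an aromatic ring, as here, therefore gives no reason to expect a lower number for compound 4.

The step of a 1.4-fold higher number from compound 1 to compound 4 (0.14 log units; within the scatter) is expected to stay within the usual scatter, if anything towards a higher number. Compound 4 is expected at 25 ug/mL, with a range from 10 ug/mL to 60 ug/mL.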

Compound 4, concentration for 50% growth inhibition: 7.4 ug/mL
Beside the measured number, compound 4's estimate is 3.4-fold (0.53 log units) above it; the whole stated range lies above it.
By their numbers in this assay, from the lowest: compound 3; then compound 4; then compounds 1 and 2 (each within the scatter of the next).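

In this assay the amine nitrogen of compound 1 now has a single-change step that can be read: cyclohexyl in place of 4-chlorobenzyl gives a 2.4-fold lower number from compound 1 to compound 4 (0.39 log units; beyond the scatter), a modest change. Within the data shown here, the group on this nitrogen therefore moves the number, and the six-membered aromatic ring with its chlorine is not required there for a lower number, which the earlier compounds could not show, as no two of them differ in one place only. Among these compounds, nothing measured here accounts for the step, and the single pair does not separate the loss of the chlorine from the change of ring.

An unsubstituted benzyl on the same nitrogen would separate those two parts of the change, while a cyclopentyl or an open n-hexyl chain would test whether the cyclohexyl ring itself matters. Also open, on these data alone, is whether the same exchange gives a step of similar direction and size on the core of compound 3, which carries a second 4-chlorophenyl and a methylpiperazine in place of this secondary amine.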